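Amino to 3-(dimethylamino)propoxy on the shared core

The source may report more compounds than this note shows. Statements on the series, on what has been measured and on what is new or still open speak of the compounds shown alone.

Measured in an ADME assay on BJ cells (Homo sapiens) for cytotoxicity, with a stated time of 72 h; on this read-out lower numbers stand for an effect already at smaller amounts and higher numbers for an effect only at larger amounts of compound:
- Compound 1 `Nc1cc2c(-n3nc(-c4ccccn4)nc3N)ncnc2cc1Cl`: 27000 nM
- Compound 2 `COc1cc2ncnc(-n3nc(-c4ccccn4)nc3N)c2cc1N`: "not determined" (no result reported)
- Compound 3 `COc1cc2ncnc(-n3nc(C4CCCCC4)nc3N)c2cc1OC`: > 27000 nM, a limit of the assay

Going by these compounds, compound 2 has no single number in this assay, so its standing remains open. Apart from compound 1, the series offers only (the limit of > 27000 nM in this assay, at which 1 of the 3 values shown sits).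

The next structure is compound 4 `COc1cc2ncnc(-n3nc(-c4ccccn4)nc3N)c2cc1OCCCN(C)C`. The change 3-(dimethylamino)propoxy in place of amino on an aromatic carbon puts 3-(dimethylamino)propoxy in place of amino on an aromatic carbon, ortho to a methoxy group.

Among the compounds with values here, no measured step gives a size for this change. A modest step towards lower numbers is expected in this assay, with compound 1 at 27000 nM as the only numerical reference. For compound 4 the estimated value is 15000 nM, with an expected range of 5000 nM to 30000 nM.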

Compound 4, half-maximal effective concentration: > 25000 nM
Compound 4 was reported as a limit; the forecaster's own chance of this, stated with the estimate: 45%; middle value at least 1.6-fold (0.22 log units) from the limit.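

Within the data shown here, no step from compound 2 to compound 4 can be read: compound 2 has no number, and compound 4 gives only a limit, > 25000 nM. Going by these compounds, the size of any effect of replacing amino with 3-(dimethylamino)propoxy on the shared core remains open.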